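Aryl swap on the pyridazinone nitrogen: outlook for compound 3

This account rests on a few compounds, and the source may have more. Where it says the series, first, only, none or still open, it means among the compounds named here.

Within the data shown here, compound 2 `Cc1cc(=O)n(-c2ccccc2C(F)(F)F)nc1C(=O)Nc1ccc(Oc2ncnc3ccsc23)c(F)c1` is the only member of the series with a number in a functional assay on HepG2 cells (Homo sapiens) for cytotoxicity, read by MTT assay, with a stated time of 72 h; on this read-out higher numbers stand for weaker inhibition and lower numbers for stronger inhibition; compound 2 gives 9380 nM. Compound 1 `CNC(=O)c1cc(Oc2ccc(NC(=O)c3nn(-c4ccccc4C(F)(F)F)c(=O)cc3C)cc2F)ccn1` sits at a limit of the assay, > 40000 nM, and returns no number. Among the measured compounds shown here, the one step with both ends known is an at least 4.2-fold lower number from compound 1 to compound 2 (0.62 log units; beyond the scatter), a change at the aryl ether oxygen; its size rests on the limit of > 40000 nM in this assay, at which 1 of the 2 values shown sits, and is therefore only a lower bound.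

Compound 3 `Cc1ccc(-n2nc(C(=O)Nc3ccc(Oc4ncnc5ccsc45)c(F)c3)c(C)cc2=O)cc1` differs from compound 2 at another place: 4-methylphenyl in place of 2-(trifluoromethyl)phenyl on an aromatic nitrogen. For the measured compounds named here, no measured step touches the aryl group on the aromatic nitrogen, so the series gives no ground for a shift in either direction beyond the scatter, and the estimate for compound 3 is anchored on compound 2 with a wide range. Compound 3 is expected to give about 12000 nM in this assay, between 3000 nM and 40000 nM. The expected step is a 1.3-fold higher number from compound 2 to compound 3 (0.11 log units; within the scatter), essentially flat. A limit rather than a number, as with compound 1 at the limit of > 40000 nM in this assay, at which 1 of the 2 values shown sits, remains possible.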

Compound 3, half-maximal inhibitory concentration: 17300 nM
Compound 3: the middle estimate sits 1.4-fold (0.16 log units) below what was measured, within the range that was stated.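

The aryl group on the aromatic nitrogen now has its first measured step: in this assay, the change gives a 1.8-fold higher number from compound 2 to compound 3 (0.27 log units; within the scatter). With 4-methylphenyl in place of 2-(trifluoromethyl)phenyl, the trifluoromethyl group proves unnecessary for a measured number in this assay, and the swap gives no shift that can be told from the scatter. Unlike the step at the aryl ether oxygen, this one has a number at both ends, whereas the size of the earlier step remains only a bound: the limit of > 40000 nM in this assay, at which 1 of the 3 values shown sits.

One step cannot separate the change of substituent from the change in its place on the phenyl ring, since 2-(trifluoromethyl)phenyl and 4-methylphenyl differ in both. From the compounds shown here alone, it remains open how 2-methylphenyl, 4-(trifluoromethyl)phenyl or unsubstituted phenyl would read against compound 2 and compound 3, and whether an amine, a carboxylic acid or a longer chain on that ring would move the number beyond the scatter.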